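This account rests on a few compounds, and the source may have more. Where it says the series, first, only, none or still open, it means among the compounds named here.

Compound 1 `COc1ccc(C2=NN(C3=NC(=O)/C(=C4\C(=O)Nc5ccc(Br)cc54)S3)C(c3ccc(OC)cc3)C2)cc1` gives 200 nM in a functional assay on cells (Cancer cell lines, Homo sapiens) for cytotoxicity, read by sulforhodamine B assay, with a stated time of 48 h; a lower number here means a stronger inhibitor of growth, a higher number a weaker inhibitor of growth. Compound 2 `COc1ccc(C2=NN(C3=NC(=O)/C(=C4\C(=O)Nc5ccc(Cl)cc54)S3)C(c3ccc(OC)cc3)C2)cc1` gives 190 nM in the same measurement. Compound 3 `COc1ccc(-c2cc(-c3ccc(Cl)cc3)n(C3C(=O)Nc4ccc(Br)cc43)n2)cc1` gives 9200 nM.

The three measured compounds fall into two groups built on different cores. Compound 1 and compound 2 share one core; compound 3 is built on another, and the difference between the two cores is not broken down here. Compound 3 stands at the highest number of the three, and its distance from both compound 1 and compound 2 is beyond the usual scatter of this assay.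

Within the first core, the only change is chloro in place of bromo on an aromatic carbon. That step is a 1.1-fold lower number from compound 1 to compound 2 (0.02 log units; within the scatter), which places the two compounds within the scatter of each other, so no order between them can be read.

Compound 4 `COc1ccc(-c2cc(-c3ccc(Cl)cc3)n(C3C(=O)Nc4ccc(Cl)cc43)n2)cc1` has not yet been measured. It differs from compound 3 by chloro in place of bromo on an aromatic carbon. The surroundings of the exchange are described in the same words as for the pair of compound 1 and compound 2, so this is the same change carried onto the core of compound 3. Because the measured step of a 1.1-fold lower number from compound 1 to compound 2 (0.02 log units; within the scatter) was small, the step of a 1.1-fold lower number from compound 3 to compound 4 (0.03 log units; within the scatter) is expected to be small as well, with compound 4 expected to stay near the level of compound 3. Compound 4 is estimated at 8500 nM, between 4500 nM and 17000 nM.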

Compound 4, concentration for 50% growth inhibition: 3750 nM
For compound 4 the middle estimate is 2.3-fold (0.36 log units) above the measured one; measured number below the stated range.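

On the core of compound 3, chloro in place of bromo on an aromatic carbon gives in this assay a 2.5-fold lower number from compound 3 to compound 4 (0.39 log units; beyond the scatter), a modest step, while the same exchange on the core of compound 1 gives a 1.1-fold lower number from compound 1 to compound 2 (0.02 log units; within the scatter). Although only the first of these steps lies beyond the scatter, the gap between them does not, so the two cores cannot be said to respond differently to this change: the same change on two cores in this assay, a 1.1-fold lower number (0.02 log units; within the scatter) from compound 1 to compound 2 and a 2.5-fold lower number (0.39 log units; beyond the scatter) from compound 3 to compound 4, 2.3-fold (0.37 log units) apart, within the scatter of two such steps. This shows that, across these two pairs, the exchange behaves in a way consistent with carrying over from one core to the other, but it does not show that the step is truly larger on the core of compound 3, and two pairs set no rule for any further core in this series.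

The compounds shown carry only bromo or chloro at this place, so they leave open what fluoro, a methoxy group, an amine or a carboxylic acid would do there. They also leave open whether the close match between the two steps would hold for an exchange made elsewhere on either core.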